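Aryl versus acetyl on the triazole-bound chain carbon

The source may report more compounds than this note shows. Statements on the series, on what has been measured and on what is new or still open speak of the compounds shown alone.

Compound 3 `CC(=O)Cn1cc(CNC(=O)c2cnc(Nc3ccc(C#N)cc3)cc2Oc2c(C)cc(C)cc2C)nn1` gives 19400 nM in an ADME assay on MT4 cells (Homo sapiens) for cytotoxicity, read by MTT assay, with a stated time of 5 days (on this read-out lower numbers stand for higher toxicity in this test and higher numbers for lower toxicity in this test), the lowest of the two numbers shown. Compound 2 `Cc1cccc(Cn2cc(CNC(=O)c3cnc(Nc4ccc(C#N)cc4)cc3Oc3c(C)cc(C)cc3C)nn2)c1` gives 114000 nM in this assay. Compound 1 `Cc1cc(C)c(Oc2cc(Nc3ccc(C#N)cc3)ncc2C(=O)NCc2cn(Cc3ccccc3F)nn2)c(C)c1` reaches only the assay limit of > 222000 nM in this assay, not a number.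

Compound 4 `Cc1cc(C)c(Oc2cc(Nc3ccc(C#N)cc3)ncc2C(=O)NCc2cn(Cc3cccc(F)c3)nn2)c(C)c1` differs from compound 3 by 3-fluorophenyl in place of acetyl on a saturated chain carbon bound to an aromatic nitrogen. Among the compounds with values here, two measured steps bear on this change, both running the other way: an at least 11-fold lower number from compound 1 to compound 3 (1.05 log units; beyond the scatter), and a 5.9-fold lower number from compound 2 to compound 3 (0.77 log units; beyond the scatter). Replacing the acetyl by an aryl group on that chain carbon has so far raised the number in both cases, with the 2-fluorophenyl case sitting at the limit of > 222000 nM in this assay, at which 1 of the 3 values shown sits, and the 3-methylphenyl case at a modest step. Compound 4 carries a 3-fluorophenyl, a ring of the same kind as those in compound 1 and compound 2, so a step upward in this assay beyond the scatter is expected, probably of a size between those two measured steps, and the result may again fall at the assay limit.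

For compound 4 the expected value in this assay is 150000 nM, within 60000 nM to 300000 nM, which means an expected step of a 7.7-fold higher number from compound 3 to compound 4 (0.89 log units; beyond the scatter).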

Compound 4, half-maximal cytotoxic concentration: >= 204000 nM
Compound 4: only a limit was reported (the forecaster's own chance of this, stated with the estimate: 35%); middle value at least 1.3-fold (0.13 log units) away from the limit.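

In this assay, within the data shown here, 3-fluorophenyl in place of acetyl on the saturated chain carbon bound to an aromatic nitrogen gives an at least 10-fold higher number from compound 3 to compound 4 (1.02 log units; beyond the scatter), so a third aryl case now stands apart from the acetyl compound, and the low number so far remains confined to compound 3. Fluoro in place of methyl on an aromatic carbon gives an at least 1.7-fold higher number from compound 2 to compound 4 (0.25 log units; that floor lies within the scatter), and this floor alone does not separate the two aryl compounds, so no order among the ring substituents can be drawn from it. The value of compound 4 is a limit and not a number: the limit of >= 204000 nM in this assay, at which 1 of the 4 values shown sits.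

From the compounds shown here alone, the step between compound 1 and compound 4 cannot be read, both values being limits, so the 2-fluorophenyl and 3-fluorophenyl cases cannot be ordered and the true ceiling of the aryl compounds in this assay stays unknown. Going by these compounds, it also stays open whether the lower number belongs to acetyl alone or extends to other groups without a ring on that chain carbon, such as an amine, a carboxylic acid or a longer chain.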